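Swapping 4-nitrophenyl for 2-bromophenyl: expected growth inhibition

This account rests on a few compounds, and the source may have more. Where it says the series, first, only, none or still open, it means among the compounds named here.

Measured in a functional assay on MCF7 cells (Homo sapiens) for inhibition, read by MTT assay, with a stated time of 48 h, tested at 10 uM; a higher number here means more inhibition of growth at the concentration tested, a lower number less inhibition of growth
- compound 1 `COc1ccc(COc2cc(O)c3c(=O)cc(C)oc3c2[C@H]2CCN(C)C[C@H]2O)cc1` gives 16%
- compound 2 `Cc1cc(=O)c2c(O)cc(OCc3ccc(Br)cc3)c([C@H]3CCN(C)C[C@H]3O)c2o1` gives 14%
- compound 3 `Cc1cc(=O)c2c(O)cc(OCc3ccc([N+](=O)[O-])cc3)c([C@H]3CCN(C)C[C@H]3O)c2o1` gives 39%

Compound 3 stands highest of the three, with its gaps to both others beyond the scatter. The next case is compound 4 `Cc1cc(=O)c2c(O)cc(OCc3ccccc3Br)c([C@H]3CCN(C)C[C@H]3O)c2o1`, which differs from it as follows: 2-bromophenyl in place of 4-nitrophenyl on a saturated chain carbon bound to an oxygen on an aromatic ring. Read one bond further out, this is 4-nitrobenzyl to 2-bromobenzyl.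

The nearest evidence is a number 25 percentage points higher from compound 2 to compound 3 (beyond the scatter), a modest step for nitro in place of bromo, which here would run in reverse. The step of a number 23 percentage points higher from compound 1 to compound 3 (beyond the scatter) is of similar size, while a number 2 percentage points lower from compound 1 to compound 2 (within the scatter) stays within the scatter. In these three compounds, only the nitro compound stands apart. Going by the values given here, no measured compound carries 2-bromophenyl, which leaves the effect of that group untested.

A modest fall in this assay is expected, estimated as a number 21 percentage points lower from compound 3 to compound 4 (beyond the scatter). Compound 4 is estimated at 18%, with an expected range of 6% to 34%.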

Compound 4, percent growth inhibition at one concentration: 45%
For compound 4 the middle estimate is 27 percentage points below the measured one; the whole stated range lies below it.
By their numbers in this assay, from the lowest: compounds 2 and 1 (each within the scatter of the next); then compounds 3 and 4 (each within the scatter of the next).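

In this assay, bromine on the benzyl ring does not by itself go with weak growth inhibition: 2-bromophenyl in place of 4-bromophenyl gives a number 31 percentage points higher from compound 2 to compound 4 (beyond the scatter), so where the bromine sits on this ring matters in this pair. 2-Bromophenyl in place of 4-methoxyphenyl gives a number 29 percentage points higher from compound 1 to compound 4 (beyond the scatter), and 2-bromophenyl in place of 4-nitrophenyl gives a number 6 percentage points higher from compound 3 to compound 4 (within the scatter). The nitro compound therefore no longer stands alone, and a group with no nitro can reach the same level at this position.

Nothing at hand accounts for the gap between the two bromo compounds. Still open, from the compounds shown here alone, is whether the 2-position favours other groups too, such as an amine in 2-aminophenyl or a carboxylic acid in 2-carboxyphenyl, or whether the gain belongs to bromine.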